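Swapping methoxy for bromo in compound 2

The source may report more compounds than this note shows. Statements on the series, on what has been measured and on what is new or still open speak of the compounds shown alone.

Measured in a functional assay on A549 cells (Homo sapiens) for antiproliferative activity, read by MTT assay, with a stated time of 24 h; on this read-out lower numbers stand for stronger inhibition and higher numbers for weaker inhibition:
Compound 1 `FC(F)(F)c1ccc(-c2nn(-c3ccccc3)cc2-c2nc3ccccc3[nH]2)cc1` gives 3620 nM
Compound 2 `COc1ccc(S(=O)(=O)n2c(-c3cn(-c4ccccc4)nc3-c3ccc(F)cc3)nc3ccccc32)cc1` gives 350 nM

Of these two compounds, compound 2 holds the lower number at 350 nM, and so the stronger inhibition in this assay. Compound 1 stands higher at 3620 nM, a gap well beyond the scatter. The two differ in more than one place, so their values alone do not tie that gap to any single change.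

The next compound is compound 3 `O=S(=O)(c1ccc(Br)cc1)n1c(-c2cn(-c3ccccc3)nc2-c2ccc(F)cc2)nc2ccccc21`, which keeps the structure of compound 2 except for one substituent: bromo in place of methoxy on an aromatic carbon. Bromo replaces methoxy on an aromatic carbon, para to a large group, turning the (4-methoxyphenyl)sulfonyl group into (4-bromophenyl)sulfonyl. For the measured compounds named here, no measured pair shows this change, so the expectation rests on compound 2 at 350 nM and on the modest size of the exchange.

The expected result is a 1.1-fold higher number from compound 2 to compound 3 (0.06 log units; within the scatter), a step estimated to stay within the scatter. For compound 3 the estimate is 400 nM, with an expected range from 150 nM to 1100 nM.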

Compound 3, half-maximal inhibitory concentration: 1720 nM
For compound 3 the middle estimate is 4.3-fold (0.63 log units) below the measured one; the whole stated range lies below it.
By their numbers in this assay, from the lowest: compound 2; then compound 3; then compound 1.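

In this assay, the exchange of methoxy for bromo on the aromatic carbon para to a large group gives a 4.9-fold higher number from compound 2 to compound 3 (0.69 log units; beyond the scatter), a step beyond the scatter. This is the only comparison among the compounds shown that isolates a single place, and it shows that the substituent on the arylsulfonyl ring is not a neutral spectator: with the rest of the structure held fixed, 4-methoxyphenyl gives the lower number of the pair and 4-bromophenyl the higher one. Nothing measured here bears on what lies behind this step.

The compounds shown leave open whether the step reflects the departure of methoxy, the arrival of bromo, or both, as a single exchange cannot separate the two and gives no trend across substituents. A plain phenylsulfonyl group carrying only hydrogen at this carbon, or an ethoxy, chloro, amine or carboxylic acid group in the same place, would show whether methoxy is unusual here or bromo is, and how far the number can move at this position.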